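Fluorophenyl for Chlorophenyl on the Ring Nitrogen

The compounds below may be only part of what the source reports. "The series", "measured", "known", "first", "only" and "open" are said of these compounds alone.

Measured compounds:
compound 1, `Nc1ccccc1NC(=O)c1ccc(CSC(=S)N2CCN(c3ccc(Cl)cc3)CC2)cc1`: 51.2%
compound 2, `Nc1ccccc1NC(=O)c1ccc(CSC(=S)N2CCN(Cc3ccncc3)CC2)cc1`: 59.5%

Both compounds were tested in a functional assay on HeLa cells (Homo sapiens) for antiproliferative activity, read by CCK-8 assay, with a stated time of 72 h, tested at 2 uM; a lower number here means a weaker effect, a higher number a stronger effect of the compound at the concentration tested. In this assay compound 1 gives 51.2% and compound 2 gives 59.5%. Going by the values given here, the one step between them, a number 8.3 percentage points higher from compound 1 to compound 2 (within the scatter), is within the scatter, so the two numbers cannot be placed in an order; compound 1 simply stands alongside compound 2.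

Compound 3, `Nc1ccccc1NC(=O)c1ccc(CSC(=S)N2CCN(c3ccccc3F)CC2)cc1`, differs from compound 1 as follows: 2-fluorophenyl in place of 4-chlorophenyl on an amine nitrogen in a ring. No measured step exchanges one halogen-bearing phenyl for another on this ring nitrogen; the only step shown concerns a different replacement at that position and was itself within the scatter. On this basis compound 3 is expected to stay close to compound 1, with an estimated step of a number 1.2 percentage points lower from compound 1 to compound 3 (within the scatter) that does not go beyond the scatter. The estimate for compound 3 is 50%, with a range from 32% to 68%.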

Compound 3, a percentage reported as inhibition, at one concentration (the size of the read-out at that concentration, not a potency): 17.5%
Estimate against measurement, compound 3: 32.5 percentage points above; measured number outside the range, below it.
By their numbers in this assay, from the lowest: compound 3; then compounds 1 and 2 (each within the scatter of the next).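

In this assay, going by these compounds alone, the group on this ring nitrogen matters more than the earlier compounds showed: 2-fluorophenyl in place of 4-chlorophenyl gives a large drop (a number 33.7 percentage points lower from compound 1 to compound 3 (beyond the scatter)), although the two groups have the same count of heavy atoms, donors and acceptors. 2-Fluorophenyl in place of (pyridin-4-yl)methyl also gives a large drop (a number 42 percentage points lower from compound 2 to compound 3 (beyond the scatter)), so compound 3 stands apart from both earlier compounds. No measurement given here bears on the cause of these drops.

As far as these compounds go, the halogen and its place on the phenyl ring change together in compound 3, so it remains open which of the two goes with the drop; 4-fluorophenyl and 2-chlorophenyl would separate them. From the compounds shown here alone, it also remains open how an unsubstituted phenyl or 4-methoxyphenyl on this ring nitrogen would compare.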